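Aryl swap on the methyl oxime of the pyridinylpiperazine series

The source may hold more compounds than are shown below. What is called first, only, known or untested is meant among the compounds shown, and "the series" means these compounds.

Compound 3 `CO/N=C(\CCN1CCN(c2ccccn2)CC1)c1ccc(Cl)cc1` gives 87% in a functional assay on HEK293 cells with D(4) dopamine receptor (Homo sapiens) as the target, read by FLIPR; a higher number here means a larger maximal response, a lower number a smaller maximal response. Compound 2 `CO/N=C(\CCN1CCN(c2ccccn2)CC1)c1ccccc1Cl` gives 79%, within the scatter of compound 3, while compound 1 `Cc1cc(C)cc(/C(CCN2CCN(c3ccccn3)CC2)=N/O)c1` gives 55%, beyond the scatter below compound 3. Compound 4 `CO/N=C(\CCN1CCN(c2ccccn2)CC1)c1cc(C)cc(C)c1` differs from compound 3 as follows: 3,5-dimethylphenyl in place of 4-chlorophenyl on a carbon with a double bond to nitrogen. Among the compounds with values here, the only measured step bearing on an aryl change, a number 8 percentage points higher from compound 2 to compound 3 (within the scatter), moves the chlorine around the ring without leaving the scatter; no measured step exchanges chlorine for two methyl groups. Compound 1 carries the same 3,5-dimethylphenyl but differs elsewhere, so its number is only a loose pointer. A modest decrease is therefore expected; compound 4 is estimated at 72% (range 52% to 92%), and the expected step is a number 15 percentage points lower from compound 3 to compound 4 (beyond the scatter).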

Compound 4, largest response reached (reported as efficacy), in percent of the reference or control that the assay uses: 71%
Compound 4: the middle estimate sits 1 percentage points above what was measured, within the range that was stated.
By their numbers in this assay, from the lowest: compound 1; then compounds 4, 2 and 3 (each within the scatter of the next, the first and the last beyond it).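

In this assay, within the data shown here, the exchange of 4-chlorophenyl for 3,5-dimethylphenyl gives a number 16 percentage points lower from compound 3 to compound 4 (beyond the scatter) and is the only aryl step at this carbon that lies beyond the scatter, whereas the exchange of 2-chlorophenyl for 3,5-dimethylphenyl gives a number 8 percentage points lower from compound 2 to compound 4 (within the scatter) and stays within it. With 3,5-dimethylphenyl held constant, methyl in place of hydrogen on an oxygen gives a number 16 percentage points higher from compound 1 to compound 4 (beyond the scatter) and so shows that the oxime oxygen also matters. No evidence on the cause of these steps is available.

Open: whether a methoxy group or a single methyl on the phenyl ring would hold the response, and whether 4-chlorophenyl keeps its standing when the oxygen carries hydrogen.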